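This account rests on a few compounds, and the source may have more. Where it says the series, first, only, none or still open, it means among the compounds named here.

The measured compounds, all in an ADME assay on BJ cells (Homo sapiens) for cytotoxicity, with a stated time of 72 h; a higher number here means that more compound is needed for the effect, a lower number that less compound is needed:

Compound 1, `Cc1cc(NC(=O)Nc2ccc(C)c(Cl)c2)c2ccccc2n1`, gives > 25000 nM, a limit of the assay rather than a number.
Compound 2, `Cc1ccc(NC(=O)Nc2cc(C)nc3ccccc23)cc1`, gives > 25000 nM, again a limit.
Compound 3, `Cc1cc(NC(=O)Nc2ccccc2F)c2ccccc2n1`, gives > 25000 nM, also a limit.

Where does compound 2 stand? Its value is only a limit, and the two other values shown are limits as well, so no order among the three compounds can be read. All of them sit at the limit of > 25000 nM in this assay, at which 3 of the 3 values shown sit.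

The unmeasured compound is compound 4, `Cc1cc(NC(=O)Nc2ccc(C(N)=O)cc2)c2ccccc2n1`. It differs from compound 2 in a single place: carbamoyl in place of methyl on an aromatic carbon.

Two measured steps exist, a step that the two limits leave unreadable from compound 1 to compound 2 and a step that the two limits leave unreadable from compound 2 to compound 3, and both run between limits, so their size and direction stay hidden. Neither of them involves a carbamoyl group. Within the data shown here, there is thus no measured step from which a change of any size or direction in this assay can be expected; what the data show is only that every compound so far reached the limit without a reading.

Compound 4 is expected to give about 30000 nM, with a range from 10000 nM to 100000 nM. This corresponds to an expected step that the limit leaves unreadable from compound 2 to compound 4, and a limit rather than a number remains the most likely outcome.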

Compound 4, half-maximal effective concentration: > 25000 nM
Compound 4: only a limit was reported; the forecaster's own chance of this, stated with the estimate: 80%; the middle value does not contradict the limit.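

In this assay compound 4 gives > 25000 nM as a limit and not a number. Compound 2 also stands at a limit, so no step can be read between compound 2 and compound 4, and the result sits with the others: the limit of > 25000 nM in this assay, at which 4 of the 4 values shown sit.

The compounds shown leave open whether any of these changes alters the cytotoxicity reading at all.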